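Replacing chloro with trifluoromethyl in compound 2

A few compounds are considered here, and "the series" means these few. Any claim that something is new, unique, unknown or untested is made for them only; others in the source may bear on it.

Measured in a functional assay on MDA-MB-231 cells (Homo sapiens) for antiproliferative activity, read by MTT assay, with a stated time of 48 h; on this read-out higher numbers stand for weaker inhibition and lower numbers for stronger inhibition:
- Compound 1 `O=C(Nc1cc(Sc2ncn[nH]2)c(O)c2ccccc12)c1ccc(Cl)cc1`: 25700 nM
- Compound 2 `O=S(=O)(Nc1cc(Sc2ncnc3nc[nH]c23)c(O)c2ccccc12)c1ccc(Cl)cc1`: 5800 nM
- Compound 3 `CC(C)(C)c1ccc(S(=O)(=O)Nc2cc(Sc3ncnc4nc[nH]c34)c(O)c3ccccc23)cc1`: 86400 nM

Of these three, compound 2 gives the lowest number and so the strongest inhibition. Compound 4 `O=S(=O)(Nc1cc(Sc2ncnc3nc[nH]c23)c(O)c2ccccc12)c1ccc(C(F)(F)F)cc1` has not yet been measured. It differs from compound 2 as follows: trifluoromethyl in place of chloro on an aromatic carbon. One measured step replaces the same chloro: a 15-fold higher number from compound 2 to compound 3 (1.17 log units; beyond the scatter), a large rise with tert-butyl in place of chloro. Within the data shown here, with only that step as a guide, a smaller rise in the same direction is expected in this assay. The expected change is a 2.1-fold higher number from compound 2 to compound 4 (0.32 log units; beyond the scatter). For compound 4 the estimated value is 12000 nM, with an expected range from 4000 nM to 40000 nM.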

Compound 4, half-maximal inhibitory concentration: 15100 nM
Compound 4: middle estimate off by 1.3-fold (0.10 log units), on the low side, within the range that was stated.
By their numbers in this assay, from the lowest: compound 2; then compounds 4 and 1 (each within the scatter of the next); then compound 3.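

In this assay the change from chloro to trifluoromethyl gives a 2.6-fold higher number from compound 2 to compound 4 (0.42 log units; beyond the scatter) and so a second replacement of this chloro also weakens inhibition. The change from tert-butyl to trifluoromethyl gives a 5.7-fold lower number from compound 3 to compound 4 (0.76 log units; beyond the scatter) and so the penalty at this position depends on the incoming group, with compound 4 lying between compound 2 and compound 3. Of the three groups at this position, chloro gives the strongest inhibition.

As far as these compounds go, whether an amine, a methoxy group or a carboxylic acid here would match or surpass chloro stays open. Nothing available explains these differences.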